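From 2-nitrophenyl to 2,4-difluorophenyl on a sulfonyl sulfur

The compounds below may be only part of what the source reports. "The series", "measured", "known", "first", "only" and "open" are said of these compounds alone.

Measured so far in a physicochemical assay for solubility, read by HPLC (a lower number here means a less soluble compound, a higher number a more soluble compound), are these compounds
Compound 1 `O=C1NCc2ncc(-c3ccc(-c4cncc(NS(=O)(=O)c5ccc(F)cc5F)c4)s3)cc21` gives 3770 ug/mL
Compound 2 `CN1Cc2cc(-c3ccc(-c4cncc(NS(=O)(=O)c5ccc(F)cc5F)c4)s3)cnc2C1=O` gives 20300 ug/mL
Compound 3 `COc1ncc(-c2ccc(-c3cnc4c(c3)CN(C)C4=O)s2)cc1NS(=O)(=O)c1ccccc1[N+](=O)[O-]` gives 4810 ug/mL

Compound 3 at 4810 ug/mL sits within the scatter of compound 1 at 3770 ug/mL in this small set, while compound 2 gives 20300 ug/mL, beyond the scatter from compound 3. Among the measured compounds shown here, compound 4 `COc1ncc(-c2ccc(-c3cnc4c(c3)CN(C)C4=O)s2)cc1NS(=O)(=O)c1ccc(F)cc1F` is the same structure with 2,4-difluorophenyl in place of 2-nitrophenyl on a sulfonyl sulfur and no measured step covers that exchange. For the measured compounds named here, the one measured step of a 5.4-fold higher number from compound 1 to compound 2 (0.73 log units; beyond the scatter) is modest and beyond the scatter, yet it lies at another place, on an aromatic carbon, and both of its compounds already carry 2,4-difluorophenyl. It therefore gives no size for this exchange. No step beyond the scatter is expected in this assay in either direction, and the range is kept wide. The expected change is a 1.2-fold higher number from compound 3 to compound 4 (0.10 log units; within the scatter) and it remains only an estimate. For compound 4 the estimated value is 6000 ug/mL with 1800 ug/mL to 20000 ug/mL as the expected range.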

Compound 4, solubility: 18300 ug/mL
Compound 4: middle estimate off by 3.1-fold (0.48 log units), on the low side; measured number inside the range.
By their numbers in this assay, from the lowest: compounds 1 and 3 (each within the scatter of the next); then compounds 4 and 2 (each within the scatter of the next).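

In this assay, among the compounds shown here, the exchange of 2-nitrophenyl for 2,4-difluorophenyl on a sulfonyl sulfur now has a measured size, with a 3.8-fold higher number from compound 3 to compound 4 (0.58 log units; beyond the scatter) as the first step read at this place, where the earlier compounds gave none. With 2,4-difluorophenyl held constant, methoxy in place of hydrogen on an aromatic carbon gives a 1.1-fold lower number from compound 2 to compound 4 (0.05 log units; within the scatter) and so does not separate the two compounds in this assay. Nothing available bears on the cause of either step.

From the compounds shown here alone, the exchange on the sulfonyl sulfur rests on this single pair, so whether it reads the same without the methoxy group remains open. The compounds shown also leave open how a plain phenyl or a methyl group on the sulfonyl sulfur would compare with these two aryl groups.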